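A few compounds are considered here, and "the series" means these few. Any claim that something is new, unique, unknown or untested is made for them only; others in the source may bear on it.

Compounds measured in a functional assay on HCT-116 cells (Homo sapiens) for cytotoxicity, with a stated time of 48 h; on this read-out lower numbers stand for stronger inhibition of growth and higher numbers for weaker inhibition of growth:

Compound 1 `CCc1cc(-c2cc(N3C[C@H](O)[C@@H](O)C3)ccc2O)nc(N)n1` gives 1000 nM.
Compound 2 `Nc1nc(-c2cc(N3C[C@H](O)[C@@H](O)C3)ccc2O)cc(C2CCCC2)n1` gives 400 nM.
Compound 3 `Nc1nc(-c2cc(N3C[C@H](O)[C@@H](O)C3)ccc2O)cc(C2CCCNC2)n1` reaches only a limit of this assay, > 10000 nM.

Compound 2 has the lowest of the two numbers that are not limits; its nearest neighbour is compound 1, with the change a 2.5-fold lower number from compound 1 to compound 2 (0.40 log units; beyond the scatter). Compound 4 `Nc1nc(-c2cc(N3C[C@H](O)[C@@H](O)C3)ccc2O)cc(C2CCCCCC2)n1` differs from compound 2 only at one site: cycloheptyl in place of cyclopentyl on an aromatic carbon. Going by the values given here, two measured steps touch this position. Going from ethyl to cyclopentyl gave a 2.5-fold lower number from compound 1 to compound 2 (0.40 log units; beyond the scatter), whereas the piperidin-3-yl gave an at least 25-fold higher number from compound 2 to compound 3 (1.39 log units; beyond the scatter), a step that ends at the limit of > 10000 nM in this assay, at which 1 of the 3 values shown sits. Since the cycloheptyl ring keeps to carbon only, the account expects a step of a 1.3-fold lower number from compound 2 to compound 4 (0.12 log units; within the scatter) from compound 2 to compound 4, a small gain or none beyond the scatter. Compound 4 is therefore estimated at 300 nM in this assay, between 120 nM and 900 nM.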

Compound 4, concentration for 50% growth inhibition: 300 nM
For compound 4 middle estimate and measured number coincide at the digits printed; the range from low to high includes it.
By their numbers in this assay, from the lowest: compounds 4 and 2 (each within the scatter of the next); then compound 1. At a limit, above all of these: compound 3.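

Cycloheptyl in place of cyclopentyl gives a 1.3-fold lower number from compound 2 to compound 4 (0.12 log units; within the scatter), so this position accepts the larger carbon-only ring as well as the smaller one. Against the other groups, cycloheptyl gives a 3.3-fold lower number from compound 1 to compound 4 (0.52 log units; beyond the scatter) and an at least 33-fold lower number from compound 3 to compound 4 (1.52 log units; beyond the scatter). The value of compound 3 is a limit and not a number: the limit of > 10000 nM in this assay, at which 1 of the 4 values shown sits.

From the compounds shown here alone, what stays open is whether a tetrahydropyranyl ring or an N-methylpiperidinyl ring would behave like the carbon-only rings or like compound 3. A phenyl ring or a longer alkyl chain at this position also remains untested in the compounds shown.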